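Piperidine substituent change on the shared core, step 3 to 4

The source may report more compounds than this note shows. Statements on the series, on what has been measured and on what is new or still open speak of the compounds shown alone.

Measured so far in a functional assay on the whole organism for inhibition, with Rattus norvegicus as the target, read by paw edema, with stated times of 4 days, 1 h and 2 h, at a dose of 100 mg/kg by the oral route; on this read-out higher numbers stand for more inhibition at the one dose given (going by the name of the read-out) and lower numbers for less inhibition:
compound 1 `CC1CCN(c2nc(-c3ccccc3)nc3ccccc23)CC1`, 69%
compound 2 `CC1CCN(c2nc(-c3ccc(Cl)cc3)nc3ccc(Br)cc23)CC1`, 55.1%
compound 3 `CCOC(=O)C1CCN(c2nc(-c3ccccc3)nc3ccccc23)CC1`, 70.3%

Compound 3 holds the top number of the three shown in this assay, but compound 1 lies within the scatter of it, so no order between compound 3 and compound 1 is claimed. Compound 2 sits further down, and its value and that of compound 3 differ in more than one place of the structure, so the two values are simply set side by side.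

Within the data shown here, the one step measured at the same position is a number 1.3 percentage points higher from compound 1 to compound 3 (within the scatter). It shows that exchanging the group on the saturated ring carbon of the six-membered ring, at least between methyl and ethoxycarbonyl, did not move the number beyond the scatter.

Compound 4 `O=c1[nH]nc(C2CCN(c3nc(-c4ccccc4)nc4ccccc34)CC2)s1` carries a different group at that same place: a group of 6 heavy atoms (2 carbon, 2 nitrogen, 1 oxygen, 1 sulfur; one five-membered aromatic ring with 3 hetero atoms) in place of a group of 5 heavy atoms (3 carbon, 2 oxygen; no ring), on a saturated ring carbon. Among the measured compounds shown here, no measured pair covers a ring group entering here, so the only guidance is the one step at this position, which was flat. The step from compound 3 to compound 4 in this assay is therefore expected to be small, a number 5.3 percentage points lower from compound 3 to compound 4 (within the scatter), with the range kept wide for the larger change in kind.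

Compound 4 is estimated at 65% in this assay, within 48% to 82%.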

Compound 4, a percentage reported as inhibition, in the whole organism at one dose (the size of the read-out at that dose, not a potency): 12.7%
Estimate against measurement, compound 4: 52.3 percentage points above; the measured number lies below the stated range.
By their numbers in this assay, from the lowest: compound 4; then compound 2; then compounds 1 and 3 (each within the scatter of the next).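

In this assay the saturated ring carbon of the six-membered ring proves to be a place where the group can matter a great deal: the entering group with the five-membered aromatic ring gives a number 57.6 percentage points lower from compound 3 to compound 4 (beyond the scatter) and, measured against methyl, a number 56.3 percentage points lower from compound 1 to compound 4 (beyond the scatter). The earlier step of a number 1.3 percentage points higher from compound 1 to compound 3 (within the scatter) therefore describes only the exchange of methyl and ethoxycarbonyl, and that flat result does not extend to every group at this place. The data shown give no reason for the fall, and they do not assign it to the ring, the sulfur or the hydrogen-bond donor of the entering group.

The compounds shown leave open whether the low number goes with any ring at this place or only with this one, since neither a plain phenyl ring nor a five-membered aromatic ring with oxygen in place of sulfur is among them. Also open, going by these compounds, are how a carboxylic acid or an amine on the same carbon would read and whether the entering group would give a similarly low number on the core of compound 2.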